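A Hydroxyphenyl Sulfone Built from Compound 3

The source may hold more compounds than are shown below. What is called first, only, known or untested is meant among the compounds shown, and "the series" means these compounds.

Three measured compounds share one core. Compound 1 `Cn1c(=O)c(S(=O)(=O)c2ccc(F)cc2F)cc2cnc(Nc3ccc4occc4c3)nc21` gives 15000 nM in a functional assay on K562 cells (Homo sapiens) for inhibition, read by trypan blue exclusion, with a stated time of 72 h; a lower number here means a stronger inhibitor, a higher number a weaker inhibitor. Compound 2 `Cn1c(=O)c(S(=O)(=O)c2ccc(F)cc2)cc2cnc(Nc3cccc4[nH]ccc34)nc21` gives 750 nM in this assay. Compound 3 `Cn1c(=O)c(S(=O)(=O)Cc2ccc(F)cc2F)cc2cnc(Nc3ccc4[nH]ccc4c3)nc21` gives 1000 nM in this assay, the second highest of the three numbers; compound 2 sits nearest, within the scatter, while compound 1 lies furthest, beyond it. Compound 4 `Cn1c(=O)c(S(=O)(=O)c2ccc(O)cc2)cc2cnc(Nc3ccc4[nH]ccc4c3)nc21` is not yet measured. It differs from compound 3 by 4-hydroxyphenyl in place of 2,4-difluorobenzyl on a sulfonyl sulfur. For the measured compounds named here, no step between measured compounds is recorded, so the direction rests on little. Compound 2 gives 750 nM with a related sulfonyl group. The step from compound 3 to compound 4 is therefore expected to be a 1.4-fold lower number from compound 3 to compound 4 (0.15 log units; within the scatter), not beyond the scatter. Compound 4 is estimated at 700 nM, between 150 nM and 3500 nM.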

Compound 4, half-maximal inhibitory concentration: 100 nM
Compound 4: the middle estimate sits 7.0-fold (0.85 log units) above what was measured; measured number outside the range, below it.
By their numbers in this assay, from the lowest: compound 4; then compounds 2 and 3 (each within the scatter of the next); then compound 1.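

In this assay, for the compounds shown here, the change on the sulfonyl sulfur gives a 10-fold lower number from compound 3 to compound 4 (1.00 log units; beyond the scatter), the first step read between compounds that differ in one place, so the group held there can shift this number on the shared core. The swap changes the 2,4-difluorobenzyl group to 4-hydroxyphenyl as a whole, so the step cannot be assigned to any one part of that group. Nothing available explains the step. Still open, going by these compounds, is how an unsubstituted phenyl, a 4-methoxyphenyl or a 4-aminophenyl on the sulfonyl sulfur would compare with 4-hydroxyphenyl.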